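The source may report more compounds than this note shows. Statements on the series, on what has been measured and on what is new or still open speak of the compounds shown alone.

Compound 1 `Cc1ccc(-c2nnc(-c3ccc(CN4CCN(C)CC4)c(C(F)(F)F)c3)o2)cc1Nc1nccc(-c2cccnc2)n1`; compound 2 `Cc1ccc(-c2nnc(-c3ccc(C)c(C(F)(F)F)c3)o2)cc1Nc1nccc(-c2cccnc2)n1`; compound 3 `Cc1nnc(-c2ccc(C)c(Nc3nccc(-c4cccnc4)n3)c2)o1`.

In a functional assay on K562 cells (Homo sapiens) for inhibition, read by MTT assay, with a stated time of 72 h (a higher number here means a weaker inhibitor, a lower number a stronger inhibitor), compound 1 gives 510 nM. Compound 2 reaches only the limit of this assay, > 30000 nM. Compound 3 likewise reaches only the limit, > 30000 nM, so it stands at the weak end of the numbers shown, at the limit of > 30000 nM in this assay, at which 2 of the 3 values shown sit. Among the measured compounds shown here, the move an at least 58-fold higher number from compound 1 to compound 2 (1.76 log units; beyond the scatter) is the one readable step. Compound 4 `Cc1ccc(-c2nnc(-c3ccc(F)c(C(F)(F)F)c3)o2)cc1Nc1nccc(-c2cccnc2)n1` differs from compound 3 by 4-fluoro-3-(trifluoromethyl)phenyl in place of methyl on an aromatic carbon. The step that the two limits leave unreadable from compound 2 to compound 3 is the one that bears on this change, and compound 2, which carries 4-methyl-3-(trifluoromethyl)phenyl on that carbon, sits at the limit. Compound 4 is therefore expected to remain at or near the limit, with a number no higher from compound 3 to compound 4 (the limit leaves the size open) not readable, and its estimate is 30000 nM, from 8000 nM to 100000 nM.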

Compound 4, half-maximal inhibitory concentration: 29700 nM
For compound 4 the middle estimate is 1.0-fold (0.00 log units) above the measured one, within the range that was stated.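

In this assay, fluoro in place of (4-methylpiperazin-1-yl)methyl on an aromatic carbon gives a 58-fold higher number from compound 1 to compound 4 (1.77 log units; beyond the scatter), so the loss of that group now has a readable size with a small replacement as well as a limit with methyl. The other two steps are a number no higher from compound 2 to compound 4 (the limit leaves the size open) and a number no higher from compound 3 to compound 4 (the limit leaves the size open); neither can be read, because the starting compound of each stands at a limit: the limit of > 30000 nM in this assay, at which 2 of the 4 values shown sit.

The compounds shown leave open whether a morpholin-4-ylmethyl or dimethylaminomethyl group in that place would bring the number back towards that of compound 1. They also leave open whether the piperazine needs its 4-methyl group.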